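Working notes: from compound 1 to compound 4

The source may hold more compounds than are shown below. What is called first, only, known or untested is meant among the compounds shown, and "the series" means these compounds.

Measured in a functional assay on Jurkat cells (Homo sapiens) for antiproliferative activity, read by MTT assay, with a stated time of 72 h; a higher number here means a weaker inhibitor, a lower number a stronger inhibitor:
- compound 1 `COc1cc(C(=O)c2sc3ccccc3c2-c2ccc(SC)cc2)cc(OC)c1OC`: 1900 nM
- compound 2 `COc1ccccc1-c1c(C(=O)c2cc(OC)c(OC)c(OC)c2)sc2ccccc12`: 2900 nM
- compound 3 `COc1ccc(-c2c(C(=O)c3cc(OC)c(OC)c(OC)c3)sc3ccccc23)cc1C`: > 10000 nM, a limit of the assay

Going by the values given here, compound 1 holds one of only two numeric values, and the gap between them is small: a 1.5-fold higher number from compound 1 to compound 2 (0.18 log units; within the scatter).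

Compound 4 `COc1cc(C(=O)c2sc3ccccc3c2Nc2ccc(C)cc2)cc(OC)c1OC` carries (4-methylphenyl)amino in place of 4-(methylsulfanyl)phenyl on an aromatic carbon.

Two measured swaps at this carbon bear on the change: a 1.5-fold higher number from compound 1 to compound 2 (0.18 log units; within the scatter), and an at least 5.2-fold higher number from compound 1 to compound 3 (0.72 log units; beyond the scatter). Neither tests an amino-linked group, so the outcome is open in both directions. In this assay no step beyond the scatter is expected, the estimate being a 1.3-fold higher number from compound 1 to compound 4 (0.12 log units; within the scatter). Compound 4 is expected at 2500 nM, with an estimated range of 400 nM to 10000 nM.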

Compound 4, half-maximal inhibitory concentration: 1700 nM
Estimate against measurement, compound 4: 1.5-fold (0.17 log units) above; the range from low to high includes it.
By their numbers in this assay, from the lowest: compounds 4, 1 and 2 (each within the scatter of the next). At a limit, above all of these: compound 3.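

In this assay a nitrogen-linked group serves at this carbon as well as the directly attached aryl groups: a 1.1-fold lower number from compound 1 to compound 4 (0.05 log units; within the scatter) and a 1.7-fold lower number from compound 2 to compound 4 (0.23 log units; within the scatter) both stay within the scatter, so the link to the 4-methylphenyl ring shows no penalty here. Beyond the scatter lies only an at least 5.8-fold lower number from compound 3 to compound 4 (0.76 log units; beyond the scatter) and that step rests on a limit for compound 3: the limit of > 10000 nM in this assay, at which 1 of the 4 values shown sits.

The compounds shown leave open whether an oxygen or methylene link at this carbon, or a carboxylic acid on the phenyl ring, would keep these numbers.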